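Chloro in place of nitro on the phenyl group

A few compounds are considered here, and "the series" means these few. Any claim that something is new, unique, unknown or untested is made for them only; others in the source may bear on it.

- compound 1 `Cc1cc(Nc2cc(N3CCN(C)CC3)nc(Nc3ccc(S(N)(=O)=O)cc3)n2)n[nH]1`: 24000 nM
- compound 2 `Cc1cc(Nc2cc(N3CCN(C)CC3)nc(Nc3cccc([N+](=O)[O-])c3)n2)n[nH]1`: 4320 nM

In a functional assay on NCI-N87 cells (Homo sapiens) for antiproliferative activity, read by CCK-8 assay, with a stated time of 72 h (a higher number here means a weaker inhibitor, a lower number a stronger inhibitor), compound 2 has the lower of the two numbers, at 4320 nM. Compound 3 `Cc1cc(Nc2cc(N3CCN(C)CC3)nc(Nc3cccc(Cl)c3)n2)n[nH]1` carries chloro in place of nitro on an aromatic carbon, meta to a large group: chloro in place of nitro on an aromatic carbon. Among the measured compounds shown here, only one measured step bears on this, a 5.6-fold lower number from compound 1 to compound 2 (0.74 log units; beyond the scatter), made on the same phenyl group. A smaller step is expected here, probably toward a lower number and not beyond the scatter. The expected change is a 1.4-fold lower number from compound 2 to compound 3 (0.16 log units; within the scatter). For compound 3 the estimated value is 3000 nM, with an expected range of 1100 nM to 8500 nM.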

Compound 3, half-maximal inhibitory concentration: 1770 nM
Estimate against measurement, compound 3: 1.7-fold (0.23 log units) above; low and high end bracket the measured number.
By their numbers in this assay, from the lowest: compound 3; then compound 2; then compound 1.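

In this assay the nitro group is not needed at this aromatic carbon: chloro in its place gives a 2.4-fold lower number from compound 2 to compound 3 (0.39 log units; beyond the scatter) and so a lower number with one heavy atom instead of three and no hydrogen-bond acceptors. Replacing the whole aryl group gives a 14-fold lower number from compound 1 to compound 3 (1.13 log units; beyond the scatter) and makes 3-chlorophenyl the best of the three groups shown. Nothing available explains these gains.

From the compounds shown here alone, whether a methyl, a methoxy or an amine on this carbon would go lower remains open. The step from 4-sulfamoylphenyl also changes group and ring position together, so their separate contributions cannot be told apart.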